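This account rests on a few compounds, and the source may have more. Where it says the series, first, only, none or still open, it means among the compounds named here.

Measured so far:
compound 1 `O=C(Nc1cccc(-n2cc(-c3ccncc3)c(-c3cc(O)cc(Cl)c3)n2)c1)Nc1ccc(Cl)c(C(F)(F)F)c1`, -29.8%
compound 2 `O=C(Nc1cccc(-n2cc(-c3ccncc3)c(-c3cc(O)cc(Cl)c3)n2)c1)Nc1ccc(Cl)c(Cl)c1`, -72.1%
compound 3 `COc1cc(Cl)cc(-c2nn(-c3cccc(NC(=O)Nc4cc(C(F)(F)F)cc(C(F)(F)F)c4)c3)cc2-c2ccncc2)c1`, -26.9%

Within the data shown here, in a functional assay on 786-0 cells (Homo sapiens) for inhibition, read by sulforhodamine B assay, with a stated time of 48 h, tested at 10 uM (on this read-out lower numbers stand for a stronger effect and higher numbers for a weaker effect at the one concentration tested), compound 2 gives the lowest number of the three; the nearest is compound 1, and the step of a number 42.3 percentage points lower from compound 1 to compound 2 (beyond the scatter) is the only single-point change measured. Compound 4 `COc1cc(Cl)cc(-c2nn(-c3cccc(NC(=O)Nc4ccc(Cl)c(Cl)c4)c3)cc2-c2ccncc2)c1` differs from compound 2 in one place: methyl in place of hydrogen on an oxygen on an aromatic ring. Among the measured compounds shown here, no measured step bears on this change directly; compound 1 and compound 3 differ in more than one place, and their values lie within the scatter of each other, so the effect of the methoxy on its own cannot be read from them. The change is small and leaves the urea part untouched, so no step beyond the scatter is expected; the estimated step of a number 10.1 percentage points higher from compound 2 to compound 4 (beyond the scatter) is near zero. Compound 4 is expected at about -62%, between -88% and -30%.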

Compound 4, a percentage reported as activity, at one concentration (the size of the read-out at that concentration, not a potency): 19.6%
Compound 4: middle estimate off by 81.6 percentage points, on the low side; the whole stated range lies below it.
By their numbers in this assay, from the lowest: compound 2; then compounds 1 and 3 (each within the scatter of the next); then compound 4.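

In this assay, hydroxy to methoxy on the 3-chloro-5-hydroxyphenyl group gives a number 91.7 percentage points higher from compound 2 to compound 4 (beyond the scatter), a large step, and the read-out changes sign. The exchange of a hydrogen for one methyl on this oxygen is therefore enough to take the series from a strongly negative number to a positive one, so this position is sensitive to the change. Nothing available gives a reason for this step. Still open, going by these compounds, is whether an amine or an ethoxy in place of the hydroxy would stay close to compound 2 or compound 4, and whether methoxy has the same effect with the urea part of compound 1.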